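Allyl for ethyl on the triazole nitrogen of compound 3

The source may hold more compounds than are shown below. What is called first, only, known or untested is meant among the compounds shown, and "the series" means these compounds.

Measured compounds:
compound 1, `C=CCn1c(SCC(=O)Nc2ccc(C(C)=O)cc2)nnc1-c1ccccc1`, 63%
compound 2, `CCn1c(SCC(=O)Nc2ccc(/C(C)=N/O)cc2)nnc1-c1ccc(OC)c(OC)c1`, 73%
compound 3, `CCn1c(SCC(=O)Nc2ccc(C(C)=O)cc2)nnc1-c1ccc(OC)c(OC)c1`, 66%

In a functional assay on the whole organism (strain albino) for inhibition, with Rattus norvegicus as the target, read by paw edema, with stated times of 30 min and 5 h, at a dose of 0.28 mmol/kg by the oral route (on this read-out higher numbers stand for more inhibition at the one dose given (going by the name of the read-out) and lower numbers for less inhibition), compound 3 stands second highest of the three numbers. Its nearest neighbour is compound 1, which gives 63%, and the furthest is compound 2, which gives 73%; both gaps lie within the scatter, so the three compounds are not separated on this read-out. Among the measured compounds shown here, the one step between single-point neighbours, a number 7 percentage points lower from compound 2 to compound 3 (within the scatter), concerns the acetyl oxime against the acetyl group and says nothing about the chain on the aromatic nitrogen.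

Compound 4, `C=CCn1c(SCC(=O)Nc2ccc(C(C)=O)cc2)nnc1-c1ccc(OC)c(OC)c1`, is the unmeasured member. It differs from compound 3 by vinyl in place of methyl on a saturated chain carbon bound to an aromatic nitrogen. For the measured compounds named here, no measured pair isolates this change: compound 1 carries the allyl chain but with an unsubstituted phenyl, so its value and that of compound 3 show only that the two numbers lie within the scatter of each other. Going by the values given here, with no step bearing directly on the change, the expectation is a step of no change at the digits printed from compound 3 to compound 4 (within the scatter) in this assay, that is, none beyond the scatter. Compound 4 is therefore estimated at 66%, within 54% to 78%.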

Compound 4, a percentage reported as inhibition, in the whole organism at one dose (the size of the read-out at that dose, not a potency): 64%
The estimate for compound 4 lay 2 percentage points above the measured number; the range from low to high includes it.
By their numbers in this assay, from the lowest: compounds 1, 4, 3 and 2 (each within the scatter of the next).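

In this assay, vinyl in place of methyl on a saturated chain carbon bound to an aromatic nitrogen now has a direct reading with the 3,4-dimethoxyphenyl held constant: the step is a number 2 percentage points lower from compound 3 to compound 4 (within the scatter) and so ethyl and allyl are not told apart at this position. The second pair holds the allyl chain constant and isolates the aryl group on an aromatic carbon, with a number 1 percentage points higher from compound 1 to compound 4 (within the scatter) and so 3,4-dimethoxyphenyl and phenyl are not told apart here either. No measurement at hand speaks to what lies behind either reading.

Still open, going by these compounds, is whether a longer chain such as butyl, or a chain ending in an amine or a carboxylic acid, on that same saturated chain carbon would move the number in this assay beyond the scatter. Also open, on these data alone, is how the acetyl oxime of compound 2, at 73% with the ethyl chain, would read alongside the allyl chain, and whether a phenyl bearing a fluorine or a hydroxyl group would depart from the two aryl groups seen so far.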